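Nitro in place of hydrogen on compound 3

The source may hold more compounds than are shown below. What is called first, only, known or untested is meant among the compounds shown, and "the series" means these compounds.

In a functional assay on MCF7 cells (Homo sapiens) for cytotoxicity, read by MTT assay, with a stated time of 48 h (on this read-out lower numbers stand for stronger inhibition and higher numbers for weaker inhibition), compound 3 (`C/C(=N\NC(=S)Nc1ccccc1)c1ccccn1`) gives 0.18 nM, the lowest of the three numbers and beyond the scatter from both others. Compound 4 (`C/C(=N\NC(=S)Nc1ccccc1[N+](=O)[O-])c1ccccn1`) differs from it by nitro in place of hydrogen on an aromatic carbon. The bearing step is a 23-fold lower number from compound 1 to compound 3 (1.36 log units; beyond the scatter), which is large and runs from the iodo compound 1 (`C/C(=N\NC(=S)Nc1ccccc1I)c1ccccn1`), measured at 4.1 nM. Compound 2 (`CC(=NNC(=S)Nc1ccccc1[N+](=O)[O-])c1ccccn1`) carries the same nitro group, with its double-bond geometry undefined, and gives 5.7 nM. A large rise beyond the scatter is therefore expected, estimated as a 28-fold higher number from compound 3 to compound 4 (1.44 log units; beyond the scatter). Compound 4 is estimated at 5 nM, within an expected range of 2 nM to 12 nM.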

Compound 4, half-maximal inhibitory concentration: 5.7 nM
Compound 4: the middle estimate sits 1.1-fold (0.06 log units) below what was measured, and the stated range covers the measured number.
By their numbers in this assay, from the lowest: compound 3; then compounds 1, 2 and 4 (each within the scatter of the next).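

Nitro in place of hydrogen gives a 32-fold higher number from compound 3 to compound 4 (1.50 log units; beyond the scatter), and nitro in place of iodo gives a 1.4-fold higher number from compound 1 to compound 4 (0.14 log units; within the scatter), so the rise seen with iodo at this position is not particular to iodo. Two different groups here land within the scatter of each other, and only hydrogen stands apart. Defining the double bond leaves the number in place, with no change at the digits printed from compound 2 to compound 4 (within the scatter), and the one difference to weigh there is this: the fact that one of compounds 2 and 4 is drawn with a defined configuration and the other without, at the place where they differ

From the compounds shown here alone, whether an amine or a methoxy group at this position stays near compound 3 or near compound 4 remains open. So does the effect of nitro on another carbon of the same ring.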